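The source may hold more compounds than are shown below. What is called first, only, known or untested is meant among the compounds shown, and "the series" means these compounds.

Compound 1 `COc1ccc(OC(=O)c2cn(-c3ccccc3)nc2-c2cccnc2)cc1` sits only at a limit in the numbers shown. In a functional assay on HeLa cells (Homo sapiens) for cytotoxicity, read by MTT assay, with a stated time of 48 h (a lower number here means a stronger inhibitor, a higher number a weaker inhibitor), compound 1 gives > 100000 nM, which is a limit of the assay and not a measured number. Compound 2 `Cc1ccc(C(C)C)c(OC(=O)c2cn(-c3ccccc3)nc2-c2cccnc2)c1` is its closest neighbour. In this assay compound 2 gives > 100000 nM, likewise a limit. The step that the two limits leave unreadable from compound 1 to compound 2 therefore has no readable size. Going by the values given here, both values stand at the limit of > 100000 nM in this assay, at which 2 of the 2 values shown sit, so nothing measured so far gives a foothold for how large any step might be. Compound 3 `O=C(Oc1ccc(-c2ccccc2)cc1)c1cn(-c2ccccc2)nc1-c1cccnc1` carries phenyl in place of methoxy on an aromatic carbon, phenyl in place of methoxy on an aromatic carbon. Among the compounds with values here, no measured step bears on this change, and no step beyond the scatter can be expected in this assay in either direction. Compound 3 is therefore expected to give 100000 nM, within 30000 nM to 300000 nM, most probably again as a limit. The estimate thus expects a step of a number no higher from compound 1 to compound 3 (the limit leaves the size open).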

Compound 3, half-maximal inhibitory concentration: > 100000 nM
Compound 3 ended at the assay's limit; the forecaster's own chance of this, stated with the estimate: 80%; the middle value lies on the limit itself.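

Compound 3 joins compound 1 and compound 2 at a limit of this assay rather than at a measured number, so no step among them can be read: the limit of > 100000 nM in this assay, at which 3 of the 3 values shown sit.

The compounds shown leave open how large the effect of any of these group changes is, and which change, if any, would bring a value within measurable range.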